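From Isopropyl to Sec-Butyl on Compound 3

The compounds below may be only part of what the source reports. "The series", "measured", "known", "first", "only" and "open" are said of these compounds alone.

Compound 1 `Cc1c(Cc2c(F)cccc2Cl)nc(SC(C)C)[nH]c1=O`: > 76000 nM
Compound 2 `CC(C)Sc1nc(C(C)c2c(F)cccc2Cl)cc(=O)[nH]1`: > 75000 nM
Compound 3 `Cc1c(C(C)c2c(F)cccc2Cl)nc(SC(C)C)[nH]c1=O`: > 15000 nM

All three entries come from an ADME assay on MT4 cells (Homo sapiens) for activation, read by MTT assay (on this read-out lower numbers stand for higher toxicity in this test and higher numbers for lower toxicity in this test), and each is a limit rather than an exact number. Compound 3 therefore has no exact position, only its limit of > 15000 nM.

The next compound, compound 4 `CCC(C)Sc1nc(C(C)c2c(F)cccc2Cl)c(C)c(=O)[nH]1`, changes the group on the sulfur: methyl in place of hydrogen on a saturated chain carbon, two bonds along the chain from a sulfur. This turns isopropyl into sec-butyl, with a methyl in place of hydrogen on a saturated chain carbon, two bonds along the chain from a sulfur.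

Two measured steps also add a methyl, though at other places in the molecule: a step that the two limits leave unreadable from compound 1 to compound 3, and a step that the two limits leave unreadable from compound 2 to compound 3. Neither gives a readable size, so neither offers a size or direction to carry over. No step beyond the scatter is therefore expected in this assay, and the expected step is a step that the limit leaves unreadable from compound 3 to compound 4. Another limit rather than an exact number is also likely. The estimate for compound 4 is 25000 nM, with an expected range from 9000 nM to 80000 nM.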

Compound 4, half-maximal cytotoxic concentration: > 1500 nM
Compound 4 gave a limit, no number; the forecaster's own chance of this, stated with the estimate: 80%; the middle value does not contradict the limit.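

In this assay compound 4 gives > 1500 nM as a limit, not a number. Compound 3 also has only a limit, so no step can be read between compound 3 and compound 4. The compounds shown leave open how much sec-butyl in place of isopropyl changes the result in this assay for this series.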